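This account rests on a few compounds, and the source may have more. Where it says the series, first, only, none or still open, it means among the compounds named here.

Measured compounds:
Compound 1 `O=C1C2=C(C(=O)c3ncccc31)C1(CS2)NC(=O)N(c2ccc(Cl)cc2)C1=O`, 4 nM
Compound 2 `O=C1C2=C(C(=O)c3ncccc31)C1(CS2)NC(=O)N(c2ccccc2)C1=O`, 1 nM
Compound 3 `O=C1NN(c2ccc(Cl)cc2)C(=O)C2(CSC3=C2C(=O)c2ncccc2C3=O)N1`, 110 nM

These three compounds were tested in a functional assay on MCF7 cells (Homo sapiens) for antiproliferative activity, read by MTT assay, with a stated time of 96 h; a lower number here means a stronger inhibitor, a higher number a weaker inhibitor. Compound 1 gives 4 nM, compound 2 gives 1 nM, and compound 3 gives 110 nM, the highest number of the three. Compound 1 and compound 2 differ in one place, (hydrogen in place of chloro on an aromatic carbon), and this change gave a 4.0-fold lower number from compound 1 to compound 2 (0.60 log units; beyond the scatter). The difference between the core of compound 1 and the core of compound 3 is not broken down here; their values show that compound 3 sits well above compound 1 in this assay.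

Compound 4 `O=C1NN(c2ccccc2)C(=O)C2(CSC3=C2C(=O)c2ncccc2C3=O)N1` has not yet been measured. It stands to compound 3 as compound 2 stands to compound 1: hydrogen in place of chloro on an aromatic carbon. The place of the change reads the same in both pairs, so this is the same kind of change on a different core. Since in compound 1 to compound 2 the change gave a 4.0-fold lower number from compound 1 to compound 2 (0.60 log units; beyond the scatter), a step of similar direction is expected on the core of compound 3, estimated as a 3.1-fold lower number from compound 3 to compound 4 (0.50 log units; beyond the scatter), with some allowance for the cores not being the same. Compound 4 is therefore expected to give about 35 nM in this assay, between 10 nM and 110 nM.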

Compound 4, half-maximal inhibitory concentration: 150 nM
Compound 4: the middle estimate sits 4.3-fold (0.63 log units) below what was measured; measured number above the stated range.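

In this assay, the same replacement of 4-chlorophenyl by phenyl gives a 1.4-fold higher number from compound 3 to compound 4 (0.13 log units; within the scatter), so compound 3 and compound 4 cannot be told apart on this core. The step seen on the core of compound 1 therefore did not carry over to the core of compound 3: the same change on two cores in this assay, a 4.0-fold lower number (0.60 log units; beyond the scatter) from compound 1 to compound 2 and a 1.4-fold higher number (0.13 log units; within the scatter) from compound 3 to compound 4, 5.5-fold (0.74 log units) apart, beyond the scatter of two such steps This shows that, for these two pairs, the effect of this one change depended on the core, but it does not show which feature of the cores accounts for the gap or whether other changes at this place would depend on the core in the same way.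

The compounds shown carry only chloro or hydrogen at this place on the aromatic ring, so it remains open how a methoxy group, an amine or a carboxylic acid there would read on either core. From the compounds shown here alone, it also remains open whether the two cores would part in the same way with any of these groups.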